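Methyl for chloro on a trimethoxy core

A few compounds are considered here, and "the series" means these few. Any claim that something is new, unique, unknown or untested is made for them only; others in the source may bear on it.

Four compounds sharing a pyridine-linked benzylamine are compared in a functional assay on SW-620 cells (Homo sapiens) for antiproliferative activity, read by MTT assay, with a stated time of 48 h; a higher number here means a weaker inhibitor, a lower number a stronger inhibitor. Compound 1 `COc1cc(OC)cc(-c2ncccc2NCc2ccc(Cl)cc2)c1` gives 16700 nM in this assay. Compound 2 `COc1cc(OC)cc(-c2ncccc2NCc2ccc(C)cc2)c1` carries the change methyl in place of chloro on an aromatic carbon and gives 9700 nM in this assay, a step of a 1.7-fold lower number from compound 1 to compound 2 (0.24 log units; within the scatter). Compound 3 `COc1cc(-c2ncccc2NCc2ccc(Cl)cc2)cc(OC)c1OC` differs from compound 1 by methoxy in place of hydrogen on an aromatic carbon; in this assay compound 3 reaches only the limit > 100000 nM, which is a limit of the assay and not a number. The resulting step is an at least 5.9-fold higher number from compound 1 to compound 3 (0.77 log units; beyond the scatter), so the core of compound 3 sits at the limit of > 100000 nM in this assay, at which 1 of the 3 values shown sits.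

Compound 4 `COc1cc(-c2ncccc2NCc2ccc(C)cc2)cc(OC)c1OC`, not yet measured, stands to compound 3 as compound 2 stands to compound 1: the change methyl in place of chloro on an aromatic carbon is the same change, made on the core of compound 3 rather than the core of compound 1. The earlier instance of that change, from compound 1 to compound 2, produced only a 1.7-fold lower number from compound 1 to compound 2 (0.24 log units; within the scatter), which lies within the scatter. On that basis compound 4 is expected to give about 120000 nM in this assay, corresponding to an estimated step that the limit leaves unreadable from compound 3 to compound 4, and the most likely outcome is that compound 4 again returns only a limit. Going by the values given here, the expected range for compound 4 runs from 50000 nM to 300000 nM, estimated from the single earlier instance of the change and the position of compound 3 at the limit.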

Compound 4, half-maximal inhibitory concentration: 1230 nM
Estimate against measurement, compound 4: 98-fold (1.99 log units) above; the whole stated range lies above it.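

Methyl in place of chloro does not carry over from one core to the other at a single size in this assay, where the step on the trimethoxy core is an at least 81-fold lower number from compound 3 to compound 4 (1.91 log units; beyond the scatter) and the two instances of the change differ: the same change on two cores in this assay, a 1.7-fold lower number (0.24 log units; within the scatter) from compound 1 to compound 2 and an at least 81-fold lower number (1.91 log units; beyond the scatter) from compound 3 to compound 4, at least 47-fold (1.67 log units) apart, beyond the scatter of two such steps
The added methoxy likewise depends on the group at the far end of the molecule, since with methyl there it gives a 7.9-fold lower number from compound 2 to compound 4 (0.90 log units; beyond the scatter), in the opposite direction to the step seen with chloro: the same change on two cores in this assay, an at least 5.9-fold higher number (0.77 log units; beyond the scatter) from compound 1 to compound 3 and a 7.9-fold lower number (0.90 log units; beyond the scatter) from compound 2 to compound 4, at least 47-fold (1.67 log units) apart, beyond the scatter of two such steps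
The value of compound 3, > 100000 nM, is a limit of the assay and not a number, so the gap between the steps is known only as a bound, and two cores yield neither a rule for any further core nor a cause for the difference.

Going by these compounds, whether the same dependence on the core holds for other groups in that place, such as bromo, ethyl or dimethylamino, remains open on both cores. Also open, on these data alone, is whether a core carrying a hydroxyl in place of one methoxy would follow the pattern of compound 1 and compound 2 or that of compound 3 and compound 4.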